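Methoxy to fluoro on the aromatic carbon of compound 2

A few compounds are considered here, and "the series" means these few. Any claim that something is new, unique, unknown or untested is made for them only; others in the source may bear on it.

Going by the values given here, compound 2 `COc1ccc(/C=C2\S/C(=N\c3nc(-c4ccc(Cl)cc4)cs3)NC2=O)cc1` stands at the lowest number of the two measured so far in a functional assay on MDA-MB-231 cells (Homo sapiens) for cytotoxicity, read by MTT assay, with a stated time of 72 h (on this read-out lower numbers stand for stronger inhibition and higher numbers for weaker inhibition), where compound 2 gives 300 nM; its nearest neighbour, compound 1 `Cc1ccc(/C=C2\S/C(=N\c3nc(-c4ccc(Cl)cc4)cs3)NC2=O)cc1`, gives 800 nM. Among the compounds with values here, the only step between measured compounds, a 2.7-fold lower number from compound 1 to compound 2 (0.43 log units; beyond the scatter), is the exchange of methyl for methoxy on the aromatic carbon.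

Compound 3 `O=C1N/C(=N/c2nc(-c3ccc(Cl)cc3)cs2)S/C1=C\c1ccc(F)cc1` carries the change (fluoro in place of methoxy on an aromatic carbon). Within the data shown here, no measured step exchanges methoxy for fluoro, so the single known step bears on it only indirectly: it shows that the number answers to what sits at this position, with methoxy giving the lower value. With fluoro the outcome is uncertain, and a modest rise in the number is expected rather than a further fall. The estimated step is a 2.0-fold higher number from compound 2 to compound 3 (0.30 log units; within the scatter). Compound 3 is therefore expected at about 600 nM, with a range from 250 nM to 1500 nM.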

Compound 3, half-maximal inhibitory concentration: > 50000 nM
Compound 3: a limit, no number; the forecaster's own chance of this, stated with the estimate: 3%; middle value at least 83-fold (1.92 log units) away from the limit.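

In this assay, fluoro in place of methoxy gives an at least 160-fold higher number from compound 2 to compound 3 (2.22 log units; beyond the scatter) and fluoro in place of methyl gives an at least 62-fold higher number from compound 1 to compound 3 (1.79 log units; beyond the scatter) on the same aromatic carbon. The methyl and methoxy pair showed only a modest dependence on this substituent, whereas these steps are large and show that a single exchange at this carbon can move the read-out out of the measurable range. From the compounds shown here alone, compound 3 gives > 50000 nM as a limit of the assay and not a number, so both steps are bounds and their true sizes stay unknown: the limit of > 50000 nM in this assay, at which 1 of the 3 values shown sits.

Going by these compounds, whether an amine, a hydroxyl or an ethoxy group at this carbon would sit with methyl and methoxy or with fluoro stays open. Also open, on these data alone, is whether 4-methoxyphenyl to 4-fluorophenyl has the same outcome in other cell lines.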